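This account rests on a few compounds, and the source may have more. Where it says the series, first, only, none or still open, it means among the compounds named here.

Compound 1 `COc1ccc(S(=O)(=O)N2CCc3cccc(-c4ccc([N+](=O)[O-])cc4)c32)cc1` carries a 4-nitrophenyl group on the shared core, and in a functional assay on KB cells (Homo sapiens) for inhibition, with a stated time of 72 h (on this read-out lower numbers stand for stronger inhibition and higher numbers for weaker inhibition), compound 1 gives 52.5 nM. Among the three compounds measured so far this places compound 1 second highest; its nearest neighbour is compound 3 `COc1ccc(S(=O)(=O)N2CCc3cccc(-c4ccc(C#N)cc4)c32)cc1`, which in this assay gives 31.1 nM, and the step of a 1.7-fold lower number from compound 1 to compound 3 (0.23 log units; within the scatter) stays within the scatter. Compound 2 `COc1ccc(S(=O)(=O)N2CCc3cccc(-c4cccnc4)c32)cc1`, with pyridin-3-yl in place of 4-nitrophenyl, gives 95.9 nM in this assay; the step of a 1.8-fold higher number from compound 1 to compound 2 (0.26 log units; within the scatter) is also within the scatter, while the step of a 3.1-fold lower number from compound 2 to compound 3 (0.49 log units; beyond the scatter) is the only one of the three to go beyond it, and only modestly.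

Compound 4 `COc1ccc(S(=O)(=O)N2CCc3cccc(-c4ccc(N(C)C)cc4)c32)cc1` is the next analogue of compound 1. The change is dimethylamino in place of nitro on an aromatic carbon. Going by the values given here, no measured step introduces a dimethylamino group, so the only bearing comes from the exchanges at the same aromatic carbon: nitro to cyano, within the scatter, and the swap of the whole aryl group for pyridin-3-yl, also within the scatter. Among the compounds with values here, nothing measured so far moves more than a modest amount, so compound 4 is expected to stay close to compound 1, with the step of a 1.1-fold higher number from compound 1 to compound 4 (0.06 log units; within the scatter) expected to lie within the scatter. The value of compound 4 in this assay is estimated at 60 nM, in a range from 20 nM to 200 nM.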

Compound 4, half-maximal inhibitory concentration: 539 nM
Compound 4: middle estimate off by 9.0-fold (0.95 log units), on the low side, and the stated range ends below it.
By their numbers in this assay, from the lowest: compounds 3, 1 and 2 (each within the scatter of the next, the first and the last beyond it); then compound 4.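

Dimethylamino is the first group on this aromatic carbon to produce a large shift in this assay, with a 10-fold higher number from compound 1 to compound 4 (1.01 log units; beyond the scatter) and a 17-fold higher number from compound 3 to compound 4 (1.24 log units; beyond the scatter) both far larger than any earlier exchange at this place. The exchange of the whole aryl group gives a smaller but still clear gap, as a 5.6-fold higher number from compound 2 to compound 4 (0.75 log units; beyond the scatter) shows, and compound 4 therefore stands as the weakest of the four, with every one of its steps beyond the scatter. The position thus accepts nitro and cyano with no difference beyond the scatter but does not accept every group, even though nitro and dimethylamino have the same count of heavy atoms, and nothing available here bears on why this exchange costs so much.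

From the compounds shown here alone, it remains open whether the loss is specific to dimethylamino or extends to a primary amine, a methoxy group or a hydroxyl group on the same carbon. Also open, going by these compounds, is whether a carboxylic acid or a longer chain at this place would keep the number near that of compound 3.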